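Methoxy on the benzyl group of compound 2

The compounds below may be only part of what the source reports. "The series", "measured", "known", "first", "only" and "open" are said of these compounds alone.

Of the compounds shown here, two sharing one core have been measured in a functional assay on MIA PaCa-2 cells (Homo sapiens) for antiproliferative activity, read by MTT assay, with a stated time of 48 h; a higher number here means a weaker inhibitor, a lower number a stronger inhibitor. Compound 1 `CCCCCCc1nc(N)n(CC(=O)Nc2ccccc2)c1-c1ccccc1Br` gives 8600 nM. Compound 2 `Nc1nc(Cc2ccccc2)c(-c2ccccc2Br)n1CC(=O)Nc1ccccc1` gives 5700 nM. Compound 2 thus holds the lowest of the two numbers, but the only step shown, a 1.5-fold lower number from compound 1 to compound 2 (0.18 log units; within the scatter), does not separate it from compound 1. Compound 3 `COc1ccc(Cc2nc(N)n(CC(=O)Nc3ccccc3)c2-c2ccccc2Br)cc1` differs from compound 2 by methoxy in place of hydrogen on an aromatic carbon. Among the compounds with values here, no measured step concerns this change; the one step known, from compound 1 to compound 2, exchanged a chain for a ring and stayed within the scatter, so there is no sign that this position responds strongly to substitution. For compound 3 the expectation is therefore a step of a 1.1-fold lower number from compound 2 to compound 3 (0.06 log units; within the scatter) in this assay, not beyond the scatter. Compound 3 is estimated at 5000 nM, with a range from 2000 nM to 14000 nM.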

Compound 3, half-maximal inhibitory concentration: 3200 nM
Estimate against measurement, compound 3: 1.6-fold (0.19 log units) above; low and high end bracket the measured number.
By their numbers in this assay, from the lowest: compounds 3, 2 and 1 (each within the scatter of the next, the first and the last beyond it).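

In this assay the change from benzyl to 4-methoxybenzyl gives a 1.8-fold lower number from compound 2 to compound 3 (0.25 log units; within the scatter) and so cannot be told apart from no change at this position. Against the pentyl chain, however, the 4-methoxybenzyl group gives a 2.7-fold lower number from compound 1 to compound 3 (0.43 log units; beyond the scatter) and is the only replacement shown to pass the scatter, a modest separation that the benzyl group of compound 2 did not reach. No measurement at hand bears on why these steps fall as they do.

Whether that separation depends on methoxy in particular stays open, for methoxy is the only substituent shown on this ring. A hydroxy group, a chlorine or a carboxylic acid at the same place, or a phenethyl group in place of benzyl, would show how far this position responds.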